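A few compounds are considered here, and "the series" means these few. Any claim that something is new, unique, unknown or untested is made for them only; others in the source may bear on it.

Compound 3, `Cn1ccc2c(Oc3ccc(NC(=O)c4cn(-c5ccc(Cl)cc5)c5ccccc5c4=O)cc3F)ccnc21`, gives 2120 nM in a functional assay on MCF7 cells (Homo sapiens) for inhibition, read by MTT assay, with a stated time of 72 h (on this read-out lower numbers stand for stronger inhibition and higher numbers for weaker inhibition), the highest of the three numbers measured there. Compound 2, `O=C(Nc1ccc(Oc2ccnc3[nH]ccc23)cc1)c1cn(-c2ccc(F)c(Cl)c2)c2ccccc2c1=O`, gives 1510 nM, and compound 1, `O=C(Nc1ccc(Oc2ccnc3[nH]ccc23)cc1)c1cn(-c2ccc(F)cc2)c2ccccc2c1=O`, gives 720 nM. For the measured compounds named here, the one single-point step measured, a 2.1-fold higher number from compound 1 to compound 2 (0.32 log units; beyond the scatter), concerns a different change. Compound 4, `COc1ccc(-n2cc(C(=O)Nc3ccc(Oc4ccnc5c4ccn5C)c(F)c3)c(=O)c3ccccc32)cc1`, differs from compound 3 by methoxy in place of chloro on an aromatic carbon. Going by the values given here, no measured step swaps one group on that ring for another, so there is nothing on which to base an expected direction, and the step is expected to stay within the scatter, giving a 1.1-fold lower number from compound 3 to compound 4 (0.03 log units; within the scatter). Compound 4 is therefore estimated at 2000 nM, with a range from 700 nM to 6000 nM.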

Compound 4, half-maximal inhibitory concentration: 6720 nM
For compound 4 the middle estimate is 3.4-fold (0.53 log units) below the measured one; measured number above the stated range.
By their numbers in this assay, from the lowest: compound 1; then compounds 2 and 3 (each within the scatter of the next); then compound 4.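

On a six-membered aromatic ring of carbon only, para to a large group, methoxy in place of chloro is not a neutral swap in this assay: the step is a 3.2-fold higher number from compound 3 to compound 4 (0.50 log units; beyond the scatter). For the compounds shown here, this is the only measured exchange of one group for another at this position, and it shows that the read-out responds to which group sits there, with the 4-chlorophenyl compound giving the lower number. Nothing available explains this difference.

As far as these compounds go, whether an amine or a hydroxyl group at this position would give a lower or higher number remains open. So does whether the same swap would have a similar effect on the core of compound 1.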